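Compound 3: replacing the 3-fluorophenyl group of compound 2

The source may report more compounds than this note shows. Statements on the series, on what has been measured and on what is new or still open speak of the compounds shown alone.

Compound 1 `CN1CCN(c2ccc(-c3cc4c(N5CCN(C(=O)Nc6ccc(C#N)cc6)CC5)ncnc4s3)cc2)CC1` reads 3930 nM here
Compound 2 `CN1CCN(c2ccc(-c3cc4c(N5CCN(C(=O)Nc6cccc(F)c6)CC5)ncnc4s3)cc2)CC1` reads 13200 nM here

For the measured compounds named here, in a functional assay on MDA-MB-231 cells (Homo sapiens) for antiproliferative activity, read by MTT assay, with a stated time of 48 h (on this read-out higher numbers stand for weaker inhibition and lower numbers for stronger inhibition), compound 2 has 13200 nM as the higher of the two numbers, and its only neighbour is compound 1 at 3930 nM on the stronger side. Compound 3 `CN1CCN(c2ccc(-c3cc4c(N5CCN(C(=O)Nc6ccc(Cl)c(C(F)(F)F)c6)CC5)ncnc4s3)cc2)CC1` carries 4-chloro-3-(trifluoromethyl)phenyl in place of 3-fluorophenyl on an amide-type nitrogen, which counts as 4-chloro-3-(trifluoromethyl)phenyl in place of 3-fluorophenyl on an amide-type nitrogen while the rest of the structure stays the same. Going by the values given here, only one measured step bears on this place, namely a 3.4-fold higher number from compound 1 to compound 2 (0.53 log units; beyond the scatter) and so a modest one. Among the compounds with values here, no measured compound carries the entering group, so the direction is uncertain. Compound 2 already sits at the weak end, so a modest drop is expected, an estimated 2.9-fold lower number from compound 2 to compound 3 (0.47 log units; beyond the scatter) in this assay as read here. The estimated value for compound 3 is 4500 nM within an expected range of 1300 nM to 14000 nM on this read-out.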

Compound 3, half-maximal inhibitory concentration: 2220 nM
Compound 3: middle estimate off by 2.0-fold (0.31 log units), on the high side; the range from low to high includes it.
By their numbers in this assay, from the lowest: compounds 3 and 1 (each within the scatter of the next); then compound 2.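

In this assay, 4-chloro-3-(trifluoromethyl)phenyl on the amide-type nitrogen gives a 5.9-fold lower number from compound 2 to compound 3 (0.77 log units; beyond the scatter), which shows that the weak reading of compound 2 is not shared by every substituted phenyl at this place. Set against 4-cyanophenyl, the same group gives a 1.8-fold lower number from compound 1 to compound 3 (0.25 log units; within the scatter), so these two groups cannot be told apart here, and among the three compounds only 3-fluorophenyl stands apart. Nothing available explains why the groups differ in this way. The compounds shown leave open whether 4-chlorophenyl or 3-(trifluoromethyl)phenyl alone would read like the combined group. They also leave open whether a cyclohexyl group, with no aromatic ring on that nitrogen, would keep a reading of this order.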